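The compounds below may be only part of what the source reports. "The series", "measured", "known", "first", "only" and "open" are said of these compounds alone.

Of the compounds shown here, three built on the same core have been measured in a functional assay on SW-620 cells (Homo sapiens) for inhibition, read by MTT assay, with a stated time of 72 h; on this read-out higher numbers stand for weaker inhibition and lower numbers for stronger inhibition. Compound 1 `COc1cc(NC(C)CCCNC(=O)Nc2ccc(F)cc2)c2ncccc2c1` gives 25000 nM, the highest number of the three, though its gaps to the other two are within the scatter. Within the data shown here, compound 2 `COc1cc(NC(C)CCCNC(=O)NNC(=O)Nc2cccc(C(F)(F)F)c2)c2ncccc2c1` gives 21000 nM and compound 3 `COc1cc(NC(C)CCCNC(=O)NNC(=O)Nc2cc(C(F)(F)F)cc(C(F)(F)F)c2)c2ncccc2c1` gives 16000 nM; the one step between them, a 1.3-fold lower number from compound 2 to compound 3 (0.12 log units; within the scatter), stays within the scatter. Compound 4 `COc1cc(NC(C)CCCNC(=O)Nc2ccc(O)cc2)c2ncccc2c1` differs from compound 1 by hydroxy in place of fluoro on an aromatic carbon. Among the measured compounds shown here, no measured step swaps these two groups, and the only step available concerns another group on other compounds, so nothing here points to a shift beyond the scatter. Compound 4 is therefore expected to show no change at the digits printed from compound 1 to compound 4 (within the scatter), with an estimated 25000 nM and a range of 10000 nM to 60000 nM.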

Compound 4, half-maximal inhibitory concentration: 30000 nM
Compound 4: the middle estimate sits 1.2-fold (0.08 log units) below what was measured; low and high end bracket the measured number.
By their numbers in this assay, from the lowest: compounds 3, 2, 1 and 4 (each within the scatter of the next).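

In this assay, hydroxy in place of fluoro, at the place para to a large group, gives a 1.2-fold higher number from compound 1 to compound 4 (0.08 log units; within the scatter), so this swap on the aromatic ring cannot be told apart from repeat measurements. The earlier compounds shown here offered no step at this position; this one shows that adding a hydrogen-bond donor and acceptor here leaves the number unchanged within the scatter. Nothing available bears on this result. As far as these compounds go, whether an amine or a carboxylic acid at this same place would move the number beyond the scatter remains open.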